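Hydroxy-acyl variation on the shared core: permeability notes

The compounds below may be only part of what the source reports. "The series", "measured", "known", "first", "only" and "open" are said of these compounds alone.

For the measured compounds named here, compound 1 `O=C(NCc1cc(Cl)ccc1-n1cnnn1)[C@@H]1C[C@@H]2C[C@@H]2N1C(=O)[C@H](O)Cc1ccccn1` is the weakest permeant of the three measured so far: in an ADME assay on Caco-2 cells (Homo sapiens) for permeability, read by LC-MS, in the apical to basolateral direction, with a stated time of 60 min, at pH 6.5 (a lower number here means that the compound crosses the layer more slowly, a higher number that the compound crosses the layer faster), compound 1 gives 1.2 10^-6 cm/s, the lowest of the three numbers. Compound 2 `O=C(NCc1cc(Cl)ccc1-n1cnnn1)[C@@H]1CC=NN1C(=O)[C@H](O)C1CCCCC1` gives 19 10^-6 cm/s in this assay, and compound 3 `CCCC[C@@H](O)C(=O)N1[C@@H]2C[C@@H]2C[C@H]1C(=O)NCc1cc(Cl)ccc1-n1cnnn1` gives 35 10^-6 cm/s, both well beyond the scatter from compound 1.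

Compound 4 `CC(C)(C)[C@@H](O)C(=O)N1[C@H](C(=O)NCc2cc(Cl)ccc2-n2cnnn2)C[C@@H]2C[C@@H]21` is not yet measured. It differs from compound 1 by tert-butyl in place of (pyridin-2-yl)methyl on a saturated chain carbon bound to a carbonyl carbon and an oxygen on a saturated carbon. Going by the values given here, no measured pair shows this exact change, so the size of the step must be judged from compounds 2 and 3, whose alkyl and carbocyclic hydroxy-acyl groups sit far above compound 1. A step from compound 1 to compound 4 of a 21-fold higher number from compound 1 to compound 4 (1.32 log units; beyond the scatter) is expected, upward and beyond the scatter. Compound 4 is estimated at 25 10^-6 cm/s, with a range of 10 10^-6 cm/s to 50 10^-6 cm/s.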

Compound 4, apparent permeability: 16 10^-6 cm/s
Compound 4: middle estimate off by 1.6-fold (0.19 log units), on the high side; the range from low to high includes it.
By their numbers in this assay, from the lowest: compound 1; then compounds 4, 2 and 3 (each within the scatter of the next, the first and the last beyond it).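

For the compounds shown here, on the shared core, tert-butyl in place of (pyridin-2-yl)methyl gives a 13-fold higher number from compound 1 to compound 4 (1.12 log units; beyond the scatter) in this assay, the first comparison that differs in one place. This single position can therefore carry a large step with the rest of the molecule held fixed. Nothing measured here gives a reason for the step.

The compounds shown leave open whether the step goes with the ring nitrogen or with the aromatic ring itself. Benzyl at the same place would separate the two.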